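This account rests on a few compounds, and the source may have more. Where it says the series, first, only, none or still open, it means among the compounds named here.

Working notes on the series.

Of the compounds shown here, three have been measured in an ADME assay on isolated protein for inhibition of sodium-dependent dopamine transporter (Homo sapiens), tested at 10 uM; a higher number here means more inhibition at the concentration tested (going by the name of the read-out), a lower number less inhibition. Compound 1 `Cc1ccc(C(CCCCNC(=O)Nc2ccc(Cl)c(C(F)(F)F)c2)c2ccc(C)cc2)cc1` gives 38%. Compound 2 `Cc1ccc(C(CCCCNC(=O)Nc2ccc(Cl)cc2)c2ccc(C)cc2)cc1` gives 59% in this assay. Compound 3 `O=C(NCCCCN(c1ccc(F)cc1)c1ccc(F)cc1)Nc1ccc(Cl)cc1` gives 68% in this assay, the highest of the three numbers; its gap to compound 2 lies within the scatter, so no order between compound 3 and compound 2 is claimed, while its gap to compound 1 lies beyond the scatter.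

Among the compounds with values here, the one counted step among the measured compounds is a number 21 percentage points lower from compound 2 to compound 1 (beyond the scatter), a modest step beyond the scatter. The change behind it is trifluoromethyl in place of hydrogen on an aromatic carbon.

Compound 4 `O=C(NCCCCN(c1ccc(F)cc1)c1ccc(F)cc1)Nc1ccc(Cl)c(C(F)(F)F)c1` is not yet measured. It is related to compound 3 by trifluoromethyl in place of hydrogen on an aromatic carbon. Within the data shown here, this is the same change as the one from compound 2 to compound 1, made on a different core; the difference between the core of compound 3 and the core of compound 2 is not broken down here. The change occurs twice among the compounds shown, once measured and once not.

The expectation for compound 4 rests on a single precedent: because a number 21 percentage points lower from compound 2 to compound 1 (beyond the scatter) lowered the read-out, the same change from compound 3 is expected to lower it by a comparable amount, estimated as a number 21 percentage points lower from compound 3 to compound 4 (beyond the scatter). Compound 4 is therefore estimated at 47% in this assay, with a range from 32% to 62% to allow for the scatter and for the one-example basis.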

Compound 4, a percentage reported as inhibition, at one concentration (the size of the read-out at that concentration, not a potency): 85%
Compound 4: middle estimate off by 38 percentage points, on the low side; measured number above the stated range.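

The same change, 4-chlorophenyl to 4-chloro-3-(trifluoromethyl)phenyl, now gives a number 17 percentage points higher from compound 3 to compound 4 (beyond the scatter) in this assay, and set beside the earlier step it differs in direction and does not carry over between the two cores: the same change on two cores in this assay, a number 21 percentage points lower (beyond the scatter) from compound 2 to compound 1 and a number 17 percentage points higher (beyond the scatter) from compound 3 to compound 4, 38 percentage points apart, beyond the scatter of two such steps For these two pairs, then, the step seen on the core of compound 2 does not predict the step on the core of compound 3, not even in sign. This rests on one pair per core, and it does not show which difference between the two cores goes with the reversal, nor does it give any reason for it or any rule for other cores in the series.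

The compounds shown leave open which part of the core difference matters, since no pair here separates the parts of it from one another. Also open, as far as these compounds go, is whether a nitrile or a methoxy group in place of the trifluoromethyl group, or a longer chain between the urea and the core, would show the same split between the two cores.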